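Adding a vinyl group to compound 1

The compounds below may be only part of what the source reports. "The series", "measured", "known", "first", "only" and "open" are said of these compounds alone.

Compound 1 `COc1cc(N2C(=O)CC2c2ccc(SC)cc2)cc(OC)c1OC`: 69 nM
Compound 2 `CCSc1ccc(C2C(O)C(=O)N2c2cc(OC)c(OC)c(OC)c2)cc1`: 16 nM

In a functional assay on HL-60 cells (Homo sapiens) for inhibition, read by resazurin assay, with a stated time of 72 h (a lower number here means a stronger inhibitor, a higher number a weaker inhibitor), compound 1 gives 69 nM, the higher of the two numbers and so the weaker inhibitor of the pair. Compound 3 `C=CC1C(=O)N(c2cc(OC)c(OC)c(OC)c2)C1c1ccc(SC)cc1` keeps the core of compound 1 and changes in one place: vinyl in place of hydrogen on a saturated ring carbon. For the measured compounds named here, no measured pair shows this change alone. Compound 1 and its partner differ in more than one place, so the value of compound 2, 16 nM, is only a loose guide. A moderate move towards a lower number is expected, an estimated 2.3-fold lower number from compound 1 to compound 3 (0.36 log units; beyond the scatter). For compound 3 the estimate is 30 nM, with an expected range of 8 nM to 120 nM.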

Compound 3, half-maximal inhibitory concentration: 61 nM
Compound 3: the middle estimate sits 2.0-fold (0.31 log units) below what was measured; the range from low to high includes it.
By their numbers in this assay, from the lowest: compound 2; then compounds 3 and 1 (each within the scatter of the next).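

In this assay, placing vinyl instead of hydrogen on this saturated ring carbon of the four-membered ring gives a 1.1-fold lower number from compound 1 to compound 3 (0.05 log units; within the scatter). This ring carbon therefore carries the added vinyl group with no change that can be told from the scatter. No supporting data bear on the reason for this result.

On these data alone, whether an amine or a longer chain on this same ring carbon would move the number stays open. An ethyl group there would show whether the double bond of the vinyl group matters.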